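A few compounds are considered here, and "the series" means these few. Any claim that something is new, unique, unknown or untested is made for them only; others in the source may bear on it.

In an ADME assay (Rattus norvegicus, strain Han-wistar) for metabolic stability, at a dose of 1.5 umol/kg by the intravenous route (on this read-out higher numbers stand for a longer-lived compound and lower numbers for a shorter-lived compound), three compounds have been measured so far. Compound 1 `CC(C)n1nc(-c2ccnc3[nH]c(C4CCN(CC(=O)N(C)C)CC4)cc23)ccc1=O` gives 1 h, compound 3 `CC(C)n1cc(-c2ccnc3[nH]c(C4CCN(CC(=O)N5CCCCC5)CC4)cc23)ccc1=O` gives 1.7 h, and compound 2 `COc1cc(C(=O)N2CCCC2)ccc1-c1ccnc2[nH]c(C3CCOCC3)cc12` gives 0.5 h. Compound 2 therefore holds the lowest of the three numbers: its gap to compound 1 lies within the usual scatter, while compound 3 sits beyond it. Compound 4 `COc1cc(C(=O)N2CCCC2)ccc1-c1ccnc2[nH]c(C3CCNCC3)cc12` awaits measurement. It differs from compound 2 in a single place: piperidin-4-yl in place of oxan-4-yl on an aromatic carbon. Within the data shown here, no measured pair shows this change on its own, so there is no direct guide to its effect. The expected step in this assay is a 1.4-fold higher number from compound 2 to compound 4 (0.15 log units; within the scatter), which amounts to none beyond the scatter. Compound 4 is estimated at 0.7 h, with a likely range from 0.3 h to 1.6 h.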

Compound 4, half-life: 11 h
Estimate against measurement, compound 4: 16-fold (1.20 log units) below; measured number outside the range, above it.
By their numbers in this assay, from the lowest: compounds 2, 1 and 3 (each within the scatter of the next, the first and the last beyond it); then compound 4.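

In this assay the switch from oxan-4-yl to piperidin-4-yl on this aromatic carbon gives a 22-fold higher number from compound 2 to compound 4 (1.34 log units; beyond the scatter) and so shows that this position can strongly change the half-life. The two rings have the same size and differ in one ring atom, and the entering ring brings a hydrogen-bond donor. Nothing shown here explains the rise.

As far as these compounds go, it remains open whether the hydrogen on the ring nitrogen matters, which a piperidin-4-yl with a methyl on that nitrogen could test. From the compounds shown here alone, it is also open whether the same change would have this effect on another core.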